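Amino Group Added to a Fluorophenyl Pyrrole Sulfonamide Ester

This account rests on a few compounds, and the source may have more. Where it says the series, first, only, none or still open, it means among the compounds named here.

Measured so far:
Compound 1, `CCOC(=O)c1cc(-c2ccc(Cl)cc2)n(-c2ccc(S(N)(=O)=O)cc2)c1`: 10800 nM
Compound 2, `CCOC(=O)c1cc(-c2ccc(F)cc2)n(-c2ccc(S(N)(=O)=O)cc2)c1`: 36400 nM

Both compounds were tested in a physicochemical assay for solubility, read by HPLC, in phosphate buffer, measured as kinetic solubility, at pH 7.4; a higher number here means a more soluble compound, a lower number a less soluble compound. Compound 2 stands highest of the two numbers; its nearest neighbour is compound 1, and the step of a 3.4-fold higher number from compound 1 to compound 2 (0.53 log units; beyond the scatter) lies beyond the scatter. That step is the only measured one, and it concerns a swap of a halogen on the phenyl ring.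

Compound 3, `CCOC(=O)c1cc(-c2ccc(F)cc2)n(-c2ccc(S(N)(=O)=O)cc2)c1N`, has not yet been measured. It differs from compound 2 in one place: amino in place of hydrogen on an aromatic carbon. Among the measured compounds shown here, no measured step touches this kind of change, since the one known step replaces a halogen on a different ring. The expectation therefore rests on the change itself: an amino group brings a hydrogen-bond donor and a hydrogen-bond acceptor, which in this assay tends to move the number up modestly rather than down. A small upward step, possibly no larger than the scatter, is expected for compound 3: a 1.4-fold higher number from compound 2 to compound 3 (0.14 log units; within the scatter). The estimated value for compound 3 is 50000 nM, with a range from 20000 nM to 120000 nM.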

Compound 3, solubility: 7500 nM
The estimate for compound 3 lay 6.7-fold (0.82 log units) above the measured number, and the stated range ends above it.
By their numbers in this assay, from the lowest: compounds 3 and 1 (each within the scatter of the next); then compound 2.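

In this assay, among the compounds shown here, placing an amino group on an aromatic carbon of the five-membered aromatic ring, next to the ring nitrogen and next to the ring atom that bears an ethoxycarbonyl group, gives a 4.9-fold lower number from compound 2 to compound 3 (0.69 log units; beyond the scatter) and marks the first measured change at this position. The earlier step, fluoro in place of chloro, lay elsewhere in the molecule, so only now is it clear that replacing a hydrogen atom here with a single nitrogen-bearing group can move the number by more than the usual scatter. The direction also matters: the number fell even though the amino group adds a hydrogen-bond donor and a hydrogen-bond acceptor, so counting these alone gives no safe guide at this position, and nothing available explains the drop.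

The compounds shown leave open whether the drop belongs to the amino group itself or would also appear with a methyl group, a hydroxyl group or an acetylamino group on the same carbon. They also leave open whether the step would keep its size with chloro in place of fluoro, or with a carboxylic acid in place of the ethoxycarbonyl group.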